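From Compound 2 to Compound 3: a Change on the Amide Nitrogen

A few compounds are considered here, and "the series" means these few. Any claim that something is new, unique, unknown or untested is made for them only; others in the source may bear on it.

Of the compounds shown here, two sharing one core have been tested so far. In a functional assay on NCI-H460 cells (Homo sapiens) for inhibition, read by sulforhodamine B assay, with a stated time of 48 h, tested at 0.1 uM (a lower number here means a stronger effect, a higher number a weaker effect of the compound at the concentration tested), compound 1 `COc1cc(Cl)cc(-c2nn(-c3cccc(NC(=O)Nc4ccc(Cl)c(C(F)(F)F)c4)c3)cc2-c2ccncc2)c1` gives 102%, and compound 2 `COc1cc(Cl)cc(-c2nn(-c3cccc(NC(=O)Nc4ccc(Cl)c(Cl)c4)c3)cc2-c2ccncc2)c1` gives 100%. Going by the values given here, the single step between them, a number 2 percentage points lower from compound 1 to compound 2 (within the scatter), changes nothing that the measurement can resolve. Compound 2 therefore holds the lower of the two numbers, but its nearest neighbour compound 1 sits within the scatter of it, so no order can be read between them. Both numbers say that, at the concentration tested, neither compound held back the growth of these cells to any noticeable degree.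

Compound 3 `COc1cc(Cl)cc(-c2nn(-c3cccc(NC(=O)Nc4cccc(C(F)(F)F)c4)c3)cc2-c2ccncc2)c1` differs from compound 2 by 3-(trifluoromethyl)phenyl in place of 3,4-dichlorophenyl on an amide-type nitrogen. Among the compounds with values here, only one measured step bears on this: the move from compound 1 to compound 2 also reshaped the group on the amide-type nitrogen, and it stayed within the scatter. Taking the two flat numbers as a guide, the expected change is a number 1 percentage points lower from compound 2 to compound 3 (within the scatter), that is, none beyond the scatter. Compound 3 is accordingly estimated at 99%, with an expected range from 86% to 110%.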

Compound 3, a percentage reported as activity, at one concentration (the size of the read-out at that concentration, not a potency): 102%
Compound 3: the middle estimate sits 3 percentage points below what was measured, and the stated range covers the measured number.
By their numbers in this assay, from the lowest: compounds 2, 1 and 3 (each within the scatter of the next).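

In this assay, the exchange of 3,4-dichlorophenyl for 3-(trifluoromethyl)phenyl on the amide-type nitrogen gives a number 2 percentage points higher from compound 2 to compound 3 (within the scatter), so a second change of this group also leaves the read-out unresolved. Going by these compounds alone, the new pair adds a simpler comparison, no change at the digits printed from compound 1 to compound 3 (within the scatter), in which hydrogen replaces chloro on an aromatic carbon: for the first time a substituent on this ring is removed rather than swapped, and the number stays put. Across these three compounds, then, the ring on the amide-type nitrogen has been altered in several ways without any step rising above the scatter, and nothing at hand explains this flatness.

Still open, going by these compounds, is whether a different kind of group would separate from these three, such as an amine or a carboxylic acid on this ring, or a longer chain in place of the ring itself. Also open, on these data alone, is whether any of these three compounds would differ from the others at a higher concentration, since a single concentration with no visible effect cannot rank them.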